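Acylation of the ring nitrogen in a diaryl series

A few compounds are considered here, and "the series" means these few. Any claim that something is new, unique, unknown or untested is made for them only; others in the source may bear on it.

Of the compounds shown here, three of a shared core have been measured in a functional assay on HeLa cells (Homo sapiens) for cytotoxicity, read by MTT assay, with a stated time of 72 h; on this read-out higher numbers stand for weaker inhibition and lower numbers for stronger inhibition. Compound 1 `CC(=O)N(/N=N/c1ccc(Cl)c(C(F)(F)F)c1)c1ccc(Cl)c(C(F)(F)F)c1` gives 50600 nM. Compound 2 `O=C(c1ccc(F)cc1)N(/N=N/c1ccc([N+](=O)[O-])cc1Br)c1ccc([N+](=O)[O-])cc1Br` gives 580 nM. Compound 3 `O=[N+]([O-])c1ccc(/N=N/Nc2ccc([N+](=O)[O-])cc2Cl)c(Cl)c1` gives 3010 nM. Compound 3 thus stands second of the three: it is separated from compound 2 by a gap beyond the scatter, and from compound 1 by a larger gap in the other direction, also beyond the scatter. Among the measured compounds shown here, no two measured compounds differ in one place only, so no single step has been measured.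

Compound 4 `O=C(c1ccccc1F)N(/N=N/c1ccc([N+](=O)[O-])cc1Cl)c1ccc([N+](=O)[O-])cc1Cl` is the next compound for this assay. It differs from compound 3 by (2-fluorophenyl)carbonyl in place of hydrogen on a nitrogen on an aromatic ring. For the measured compounds named here, compound 2 also carries an aryl carbonyl on this nitrogen and gives the lowest number of the three, whereas compound 1 carries a smaller acyl group on a different aryl pair and gives the highest; no pair of compounds isolates the acyl change alone.

Because compound 2 gives 580 nM, the step from compound 3 to compound 4 is expected to be a 3.0-fold lower number from compound 3 to compound 4 (0.48 log units; beyond the scatter), beyond the scatter and toward a lower number. Compound 4 is expected to give about 1000 nM, within a range from 350 nM to 3000 nM.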

Compound 4, half-maximal inhibitory concentration: 2350 nM
The estimate for compound 4 lay 2.4-fold (0.37 log units) below the measured number; measured number inside the range.
By their numbers in this assay, from the lowest: compound 2; then compounds 4 and 3 (each within the scatter of the next); then compound 1.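

In this assay, the series now has its first single step: (2-fluorophenyl)carbonyl in place of hydrogen on a nitrogen on an aromatic ring gives a 1.3-fold lower number from compound 3 to compound 4 (0.11 log units; within the scatter). On this read-out, the nitrogen of compound 3 can therefore carry this aryl carbonyl instead of its hydrogen with no difference that can be told apart from the scatter, so for this one pair the hydrogen on that nitrogen is not required for the number seen. Nothing measured here bears on why the step has this size.

As far as these compounds go, whether another group on this same nitrogen of the core of compound 3, such as acetyl, unsubstituted benzoyl or a carbonyl carrying an amine, would give a step beyond the scatter remains open, as does any separate part played by the fluorine of the (2-fluorophenyl)carbonyl. Among the compounds shown here, compound 1 and compound 2 differ from compound 3 and compound 4 in more than one place, so no steps to them can be read, and the role of the groups on the aryl rings stays unresolved.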